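The compounds below may be only part of what the source reports. "The series", "measured", "known", "first", "only" and "open" are said of these compounds alone.

Of the compounds shown here, three of one shared core have been measured in a physicochemical assay for solubility, read by LC-MS, in phosphate buffer, measured as kinetic solubility, with a stated time of 24 h, at 25 degrees C, at pH 7.4; on this read-out higher numbers stand for higher solubility and lower numbers for lower solubility. Compound 1 `Nc1cc(-c2ccc3c(N)n[nH]c3c2)nc(N)n1` gives 58000 nM. Compound 2 `Nc1nccc(-c2cc(OCc3ccccc3)c3c(N)n[nH]c3c2)n1` gives 85000 nM. Compound 3 `Nc1nccc(-c2cc(OC3CCCOC3)c3c(N)n[nH]c3c2)n1` gives 1000000 nM, the highest of the three numbers; the nearest is compound 2 and the furthest is compound 1, both beyond the scatter. Among the measured compounds shown here, the one measured step that changes a single place, a 12-fold higher number from compound 2 to compound 3 (1.07 log units; beyond the scatter), swaps the group on the oxygen on the aromatic ring.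

Compound 4 `CC(C)Oc1cc(-c2ccnc(N)n2)cc2[nH]nc(N)c12` is not yet measured. It differs from compound 3 in that same place: isopropyl in place of oxan-3-yl on an oxygen on an aromatic ring. For the measured compounds named here, no measured step swaps oxan-3-yl for isopropyl, so the step from compound 2 to compound 3 bears only loosely on it, showing that a change at this oxygen can move the number by a large amount. With nothing closer to lean on, compound 4 is expected to give 400000 nM, with a range from 100000 nM to 1000000 nM, which means an expected step of a 2.5-fold lower number from compound 3 to compound 4 (0.40 log units; beyond the scatter).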

Compound 4, solubility: 354000 nM
For compound 4 the middle estimate is 1.1-fold (0.05 log units) above the measured one, within the range that was stated.
By their numbers in this assay, from the lowest: compounds 1 and 2 (each within the scatter of the next); then compound 4; then compound 3.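

On this oxygen, isopropyl now sits between the two other groups in this assay, with a 2.8-fold lower number from compound 3 to compound 4 (0.45 log units; beyond the scatter) and a 4.2-fold higher number from compound 2 to compound 4 (0.62 log units; beyond the scatter) both beyond the scatter. Oxan-3-yl has a ring and a ring oxygen, while isopropyl has neither, and the number still stays clearly above that of benzyl, so part of the rise over compound 2 is reached without a hetero atom in the group. No supporting measurement is available to explain this order.

These compounds cannot separate the ring from its oxygen in the drop from oxan-3-yl to isopropyl, which a cyclopentyl group or an open methoxyethyl chain could help to do. As far as these compounds go, how an amine or a carboxylic acid at this position would read also stays open.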